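The source may report more compounds than this note shows. Statements on the series, on what has been measured and on what is new or still open speak of the compounds shown alone.

Measured compounds in an ADME assay on PC-3 cells (Homo sapiens) for cytotoxicity, read by WST assay, tested at 100 uM; on this read-out higher numbers stand for more inhibition at the one concentration tested (going by the name of the read-out) and lower numbers for less inhibition:
compound 2 `O=C(Nc1cccc([N+](=O)[O-])c1)C1CCCN(C(=O)c2cc(C(F)(F)F)cc(C(F)(F)F)c2)C1`: 9%
compound 1 `O=C(Nc1cccc(Oc2ccccc2)c1)C1CCCN(C(=O)c2cccc(-c3ccco3)c2)C1`: 0%

Of the compounds shown here, two sharing one core have been tested in this assay. Compound 2 `O=C(Nc1cccc([N+](=O)[O-])c1)C1CCCN(C(=O)c2cc(C(F)(F)F)cc(C(F)(F)F)c2)C1` gives 9%, and compound 1 `O=C(Nc1cccc(Oc2ccccc2)c1)C1CCCN(C(=O)c2cccc(-c3ccco3)c2)C1` gives 0%. Among the measured compounds shown here, of the two numbers, the one for compound 2 is the higher, yet the gap to compound 1 lies within the usual scatter of repeated measurements, so the two compounds cannot be told apart on these data; both show little inhibition at the single concentration tested.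

Compound 3 `O=C(Nc1cccc(Oc2nccc(C(F)(F)F)c2Cl)c1)C1CCCN(C(=O)c2cc(C(F)(F)F)cc(C(F)(F)F)c2)C1` has not yet been measured. It differs from compound 2 in one place: (3-chloro-4-(trifluoromethyl)pyridin-2-yl)oxy in place of nitro on an aromatic carbon. For the measured compounds named here, no comparable step between measured compounds exists, so there is no measured guide to the size of this change. Given that compound 2 gives 9% and compound 1 gives 0%, the expectation for compound 3 is a step of a number 5 percentage points higher from compound 2 to compound 3 (within the scatter) that stays within or only slightly beyond the scatter. Compound 3 is therefore estimated at 14%, with a range from 0% to 38%.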

Compound 3, a percentage reported as inhibition, at one concentration (the size of the read-out at that concentration, not a potency): 0%
Beside the measured number, compound 3's estimate is 14 percentage points above it, within the range that was stated.
By their numbers in this assay, from the lowest: compounds 1, 3 and 2 (each within the scatter of the next).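

In this assay, among the compounds shown here, the exchange of nitro for (3-chloro-4-(trifluoromethyl)pyridin-2-yl)oxy on an aromatic carbon, meta to a large group, gives a number 9 percentage points lower from compound 2 to compound 3 (within the scatter), and this is the first step that can be read at this position. It shows that a group of 12 heavy atoms carrying a six-membered aromatic ring can take the place of a nitro group of 3 heavy atoms, on the same core and with the same bis(trifluoromethyl)-substituted acyl part, without the read-out leaving the scatter, so on this pair the position shows no measurable response to a large change in the group it carries. No supporting measurement bears on this result, so nothing can be said about what lies behind it.

The compounds shown leave open whether an amine or a carboxylic acid on this aromatic carbon would give a number beyond the scatter from compound 2. Compound 1 differs from both compound 2 and compound 3 in more than one place, so steps to it cannot be read, and the part of the molecule on the other side of the core remains without a readable step.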